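This account rests on a few compounds, and the source may have more. Where it says the series, first, only, none or still open, it means among the compounds named here.

Measured in a functional assay on HCT-8 cells (Homo sapiens) for antiproliferative activity, read by MTT assay, with a stated time of 48 h; a higher number here means a weaker inhibitor, a lower number a stronger inhibitor:

- Compound 1 `COc1ccc2c(/C=C(\C)C(=O)c3cc(OC)c(OC)c([Se]C)c3)cn(C)c2c1`: 25 nM
- Compound 2 `COc1cc(C(=O)/C(C)=C/c2c[nH]c3ccccc23)cc([Se]C)c1OC`: 32 nM

Compound 2, at 32 nM, stands within the usual scatter of compound 1, at 25 nM, so neither of the two stands apart on these numbers.

Compound 3 `COc1cc(C(=O)/C(C)=C/c2cn(C)c3ccccc23)cc([Se]C)c1OC` has not yet been measured. It is compound 2 with methyl in place of hydrogen on an aromatic nitrogen. For the measured compounds named here, no measured pair of compounds shows this change or any other single change on its own, so the data offer no direct guide to its size. The expectation is therefore modest: no step beyond the scatter in this assay, and no firm direction. The expected change is a 1.1-fold lower number from compound 2 to compound 3 (0.06 log units; within the scatter), an estimate that stays within that scatter. For compound 3 the estimated value is 28 nM, with an expected range from 11 nM to 70 nM.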

Compound 3, half-maximal inhibitory concentration: 48 nM
Compound 3: the middle estimate sits 1.7-fold (0.23 log units) below what was measured; the range from low to high includes it.
By their numbers in this assay, from the lowest: compounds 1, 2 and 3 (each within the scatter of the next).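

In this assay, methyl in place of hydrogen on an aromatic nitrogen gives a 1.5-fold higher number from compound 2 to compound 3 (0.18 log units; within the scatter) and so stays within the scatter, which shows that a hydrogen on this nitrogen is not needed for activity in this range. For the compounds shown here, compound 3 also gives the first reading of a change on an aromatic carbon, with hydrogen in place of methoxy giving a 1.9-fold higher number from compound 1 to compound 3 (0.28 log units; within the scatter) and again no step beyond the scatter. Nothing at hand explains either result.

The compounds shown leave open whether this nitrogen would accept more than methyl, such as a longer chain like propyl or a chain ending in an amine or a carboxylic acid. They also leave open how ethoxy or fluorine would fare on the aromatic carbon that carries methoxy in compound 1.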